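The source may hold more compounds than are shown below. What is called first, only, known or untested is meant among the compounds shown, and "the series" means these compounds.

Measured compounds:
compound 1 `COc1ccc(Sc2ccccc2N2CC(C)N(CC(=O)O)CC2C)cc1`, 580 nM
compound 2 `COc1ccc(Sc2ccc(Cl)cc2N2CCN(CC(=O)O)C(C)C2)cc1`, 290 nM
compound 3 `COc1ccc(Sc2ccc(OC)cc2N2CC(C)N(CC(=O)O)CC2C)cc1`, in this assay only a limit

All three were tested in an assay for inhibition of sodium- and chloride-dependent glycine transporter 1 (Homo sapiens); on this read-out higher numbers stand for weaker inhibition and lower numbers for stronger inhibition. Compound 3 reached only the limit of the assay, > 50000 nM, so no number is known for it. Its place among the three is therefore the weakest end of the range, with compound 1 and compound 2 giving actual values. The step from compound 1 to compound 3, in which a methoxy replaces a hydrogen on an aromatic carbon, was an at least 86-fold higher number from compound 1 to compound 3 (1.93 log units; beyond the scatter). Compound 3 sits at the limit of > 50000 nM in this assay, at which 1 of the 3 values shown sits.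

Compound 4 `COc1ccc(Sc2ccc(Cl)cc2N2CC(C)N(CC(=O)O)CC2C)cc1` differs from compound 3 by chloro in place of methoxy on an aromatic carbon. Within the data shown here, no measured step replaces a methoxy by a chloro here, but compound 2 carries a chloro on its aromatic ring and gives 290 nM, while compound 1 lacks that substituent and gives 580 nM; these two compounds also differ in their piperazine, so their pair says only that a chloro-bearing compound can sit in this range. Since the methoxy in compound 3 brought an at least 86-fold higher number from compound 1 to compound 3 (1.93 log units; beyond the scatter), its removal is expected to recover much of that loss. Compound 4 is therefore expected to show a large step toward stronger inhibition, an at least 100-fold lower number from compound 3 to compound 4 (2.00 log units; beyond the scatter), with a value near 500 nM and a plausible range from 150 nM to 3000 nM.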

Compound 4, half-maximal inhibitory concentration: 1700 nM
The estimate for compound 4 lay 3.4-fold (0.53 log units) below the measured number; measured number inside the range.
By their numbers in this assay, from the lowest: compounds 2 and 1 (each within the scatter of the next); then compound 4. At a limit, above all of these: compound 3.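

At this position, meta to a large group and para to a (4-methoxyphenyl)sulfanyl group, chloro and methoxy are far from equivalent in this assay: the exchange gives an at least 29-fold lower number from compound 3 to compound 4 (1.46 log units; beyond the scatter) and shows that a substituent can stand here without the loss seen with methoxy. Chloro is still not equal to hydrogen at this place, with a 2.9-fold higher number from compound 1 to compound 4 (0.47 log units; beyond the scatter) as the measured cost, and the earlier compounds could not separate this from the change in the saturated ring, which now has its own step of a 5.9-fold higher number from compound 2 to compound 4 (0.77 log units; beyond the scatter) in the chloro series. For compound 3 there is only a limit, so the step from it remains a bound: the limit of > 50000 nM in this assay, at which 1 of the 4 values shown sits.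

As far as these compounds go, whether fluoro, a nitrile or an amine at this place would come closer to hydrogen than chloro does remains open. So does whether the methyl on the saturated ring carbon has a similar effect when hydrogen replaces the chloro.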